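The compounds below may be only part of what the source reports. "The series", "measured", "known", "first", "only" and "open" are said of these compounds alone.

Working notes on the series.

Compound 1 `COc1ccc(C[C@H]2C(=O)N[C@@H](C)C(=O)N(C)[C@H]3Cc4ccc(cc4)Oc4cc(ccc4OC)C[C@@H](C(=O)N[C@H](C)C(=O)N[C@@H](CCC(=O)O)C(=O)N2C)N(C)C3=O)cc1` gives 219 nM in a functional assay on P388 cells (Mus musculus) for cytotoxicity; a higher number here means a weaker inhibitor, a lower number a stronger inhibitor. Compound 2 `COC(=O)CC[C@@H]1NC(=O)[C@@H](C)NC(=O)[C@@H]2Cc3ccc(OC)c(c3)Oc3ccc(cc3)C[C@@H](C(=O)N2C)N(C)C(=O)[C@H](C)NC(=O)[C@H](Cc2ccc(OC)cc2)N(C)C1=O` gives 58.9 nM in this assay, and the step between them, a 3.7-fold lower number from compound 1 to compound 2 (0.57 log units; beyond the scatter), comes with the change (methyl in place of hydrogen on an oxygen next to a carbonyl group). Compound 3 `C[C@@H]1NC(=O)[C@@H](C)NC(=O)[C@@H]2Cc3ccc(O)c(c3)Oc3ccc(cc3)C[C@@H](C(=O)N2C)N(C)C(=O)[C@H](C)NC(=O)[C@H](Cc2ccccc2)N(C)C1=O` gives 42.7 nM in this assay; the difference between its core and the core of compound 1 is not broken down here. Compound 4 `COc1ccc2cc1Oc1ccc(cc1)C[C@H]1C(=O)N(C)[C@@H](C2)C(=O)N[C@H](C)C(=O)N[C@@H](C)C(=O)N(C)[C@@H](Cc2ccccc2)C(=O)N[C@@H](C)C(=O)N1C` is not yet measured in this assay; its change from compound 3 is methyl in place of hydrogen on an oxygen on an aromatic ring. This is the same kind of change as that from compound 1 to compound 2, but not the same: there the oxygen sat next to a carbonyl group, with a carbonyl carbon as its other neighbour, while here the oxygen sits on an aromatic ring, with an aromatic carbon as its other neighbour. Because the earlier step of a 3.7-fold lower number from compound 1 to compound 2 (0.57 log units; beyond the scatter) was only modest and the place differs, a smaller step, a 1.4-fold lower number from compound 3 to compound 4 (0.15 log units; within the scatter), is expected for compound 4, likely within the scatter. Compound 4 is estimated at 30 nM, with 12 nM to 90 nM as its expected range.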

Compound 4, half-maximal inhibitory concentration: 295 nM
Beside the measured number, compound 4's estimate is 9.8-fold (0.99 log units) below it; measured number above the stated range.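

In this assay, methyl in place of hydrogen on an oxygen on an aromatic ring gives a 6.9-fold higher number from compound 3 to compound 4 (0.84 log units; beyond the scatter), a step in the opposite direction to a 3.7-fold lower number from compound 1 to compound 2 (0.57 log units; beyond the scatter). Going by these compounds alone, this change therefore does not carry over as one fixed step from core to core: the same change on two cores in this assay, a 3.7-fold lower number (0.57 log units; beyond the scatter) from compound 1 to compound 2 and a 6.9-fold higher number (0.84 log units; beyond the scatter) from compound 3 to compound 4, 26-fold (1.41 log units) apart, beyond the scatter of two such steps This shows only that a result from one pair cannot be transferred to the other; it does not show whether the core or the place of the oxygen sets the step, as the two pairs differ in both and no pair here holds one of them constant.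

From the compounds shown here alone, it remains open how the oxygen on the aromatic ring of compound 3 responds to other groups, such as an ethyl group or a longer chain ending in an amine. Also open, going by these compounds, is whether hydroxy to methoxy at this place gives a step of similar direction and size on the core of compound 1.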